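This account rests on a few compounds, and the source may have more. Where it says the series, first, only, none or still open, it means among the compounds named here.

Compound 1 `C[C@@]1(O)CC(=O)OC(CSc2nc(-c3cccc(Cl)c3)c(-c3cccc(Cl)c3)[nH]2)C1` was tested in an assay on microsomes from liver for inhibition of sterol O-acyltransferase 1 (Rattus norvegicus) (a lower number here means a stronger inhibitor, a higher number a weaker inhibitor), and compound 1 gave 110 nM. Compound 3 `CC1=CC(=O)OC(CSc2nc(-c3cccc(Cl)c3)c(-c3cccc(Cl)c3)[nH]2)C1` carries the shared core of compound 1 with a group of 8 heavy atoms (6 carbon, 2 oxygen; one six-membered non-aromatic ring with 1 hetero atom) in place of a group of 9 heavy atoms (6 carbon, 3 oxygen; one six-membered non-aromatic ring with 1 hetero atom), on a saturated chain carbon bound to a sulfur; in this assay compound 3 gave 440 nM, so the change produced a 4.0-fold higher number from compound 1 to compound 3 (0.60 log units; beyond the scatter). Compound 2 `C[C@@]1(O)CC(=O)OC(CSc2nc(-c3ccccc3Cl)c(-c3ccccc3Cl)[nH]2)C1` has a core whose difference from that of compound 1 is not broken down here; in this assay compound 2 gave 140 nM, which stands within the scatter of compound 1. Compound 4 `CC1=CC(=O)OC(CSc2nc(-c3ccccc3Cl)c(-c3ccccc3Cl)[nH]2)C1` is built from compound 2 by the same change, (a group of 8 heavy atoms (6 carbon, 2 oxygen; one six-membered non-aromatic ring with 1 hetero atom) in place of a group of 9 heavy atoms (6 carbon, 3 oxygen; one six-membered non-aromatic ring with 1 hetero atom), on a saturated chain carbon bound to a sulfur), that turned compound 1 into compound 3. Because the earlier step of a 4.0-fold higher number from compound 1 to compound 3 (0.60 log units; beyond the scatter) was modest, the step of a 4.0-fold higher number from compound 2 to compound 4 (0.60 log units; beyond the scatter) is expected to be of similar size. Compound 4 is therefore estimated at 560 nM, likely between 280 nM and 1200 nM.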

Compound 4, half-maximal inhibitory concentration: 1700 nM
Compound 4: middle estimate off by 3.0-fold (0.48 log units), on the low side; measured number above the stated range.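

On the core of compound 2, the change gave a 12-fold higher number from compound 2 to compound 4 (1.08 log units; beyond the scatter) in this assay, and the steps on the two cores differ in size: the same change on two cores in this assay, a 4.0-fold higher number (0.60 log units; beyond the scatter) from compound 1 to compound 3 and a 12-fold higher number (1.08 log units; beyond the scatter) from compound 2 to compound 4, 3.0-fold (0.48 log units) apart, beyond the scatter of two such steps. The direction carried over, with a higher number on both cores, but the size did not, so a step measured on one core gave only a rough guide to the other. Two pairs cannot show how the step would behave on any further core, nor which feature of the core sets its size.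

The compounds shown leave open how the change would behave on other cores. They also leave open whether a carboxylic acid or an amine, placed on the saturated chain carbon bound to a sulfur, would keep the number as low as the group that left does.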